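A chloro step on the phenyl group

This account rests on a few compounds, and the source may have more. Where it says the series, first, only, none or still open, it means among the compounds named here.

Compound 1 `COc1ccccc1/C=C/C(=O)c1c(O)cc2occc2c1OC` at 38200 nM 
Compound 2 `C=CCc1c(O)c(C(=O)/C=C/c2ccccc2)c(OC)c2ccoc12` at 3900 nM 

In a functional assay on Hs-578T cells (Homo sapiens) for inhibition, with a stated time of 48 h (a lower number here means a stronger inhibitor of growth, a higher number a weaker inhibitor of growth), compound 2 at 3900 nM stands lowest of the two measured compounds, and compound 1 at 38200 nM lies higher, a gap beyond the scatter. These two differ in more than one place, so the gap cannot be assigned to any single change.

Compound 3 `C=CCc1c(O)c(C(=O)/C=C/c2ccc(Cl)cc2)c(OC)c2ccoc12` is compound 2 with one change, phenyl to 4-chlorophenyl. The difference chloro in place of hydrogen on an aromatic carbon is chloro in place of hydrogen on an aromatic carbon, para to a large group. Among the compounds with values here, no measured pair shows this change, so the expectation rests on little: a small step toward a lower number in this assay is expected, possibly none beyond the scatter. The expected move is a 1.3-fold lower number from compound 2 to compound 3 (0.11 log units; within the scatter) as estimated here. Compound 3 is estimated at 3000 nM with an expected range from 1000 nM to 9000 nM in this measurement.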

Compound 3, concentration for 50% growth inhibition: 4020 nM
Compound 3: middle estimate off by 1.3-fold (0.13 log units), on the low side; measured number inside the range.
By their numbers in this assay, from the lowest: compounds 2 and 3 (each within the scatter of the next); then compound 1.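

In this assay, within the data shown here, replacing phenyl with 4-chlorophenyl gives a 1.0-fold higher number from compound 2 to compound 3 (0.01 log units; within the scatter) and so provides the first comparison that differs in one place. It shows that chloro in place of hydrogen on an aromatic carbon, para to a large group, gives no step beyond the scatter in this series. No measured evidence bears on this result.

The compounds shown leave open whether an amine or a carboxylic acid on this same aromatic carbon would give a step beyond the scatter, and whether chloro elsewhere on the phenyl group would read the same. The gap between compound 1 and compound 2 also remains unassigned, since those two compounds differ in more than one place and no single change can be held responsible.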